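The source may report more compounds than this note shows. Statements on the series, on what has been measured and on what is new or still open speak of the compounds shown alone.

Compounds measured so far:
- compound 1 `CC(C(=O)N1CCN(c2ccccc2)CC1)N1C(=O)CCC1=O`: 0%
- compound 2 `CC(C(=O)N1CCN(c2ccc(F)cc2)CC1)N1C(=O)CCC1=O`: 0%

In a functional assay on the whole organism (strain Swiss) with Mus musculus as the target, in the maximal electroshock model, with a stated time of 2 h, at a dose of 100 mg/kg by the intraperitoneal route (on this read-out lower numbers stand for a weaker effect and higher numbers for a stronger effect at the one dose given), compound 1 gives 0%, and compound 2 gives 0%. Compound 1 stands level with compound 2 at the digits shown; the one step recorded, no change at the digits printed from compound 1 to compound 2 (within the scatter), lies within the scatter. Compound 3 `CC(C(=O)N1CCN(c2cccc(C(F)(F)F)c2)CC1)N1C(=O)CCC1=O` is not yet measured and differs from compound 1 by trifluoromethyl in place of hydrogen on an aromatic carbon, the group entering on an aromatic carbon of the six-membered aromatic ring of carbon only, meta to a large group. Going by the values given here, the only step that bears on it is the aromatic substitution from compound 1 to compound 2, which brought no change in this assay beyond the scatter. The present change is larger in what enters, but no other data are available, so no step beyond the scatter is expected. For compound 3 the estimate in this assay is 5%, within 0% to 30%, meaning an expected step of a number 5 percentage points higher from compound 1 to compound 3 (within the scatter).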

Compound 3, a percentage reported as activity, at one dose (the size of the read-out at that dose, not a potency): 0%
Compound 3: the middle estimate sits 5 percentage points above what was measured, within the range that was stated.
By their numbers in this assay, from the lowest: compounds 1, 2 and 3 (each within the scatter of the next).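

In this assay, trifluoromethyl in place of hydrogen on an aromatic carbon, meta to a large group, gives no change at the digits printed from compound 1 to compound 3 (within the scatter). Going by these compounds alone, until now the only aromatic change was fluoro; this step shows that a group of 4 heavy atoms at this place also leaves the read-out where it was, with compound 3 at 0%. No measurement available here speaks to the cause of this result.

With all three compounds at the same value, the series gives no ranking of aromatic substituents and no sign of which changes could matter. On these data alone, whether a methoxy group or an amine on this aromatic ring, or a longer chain in place of the methyl group of the shared core, would give a read-out above that of compound 1 remains open.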